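This account rests on a few compounds, and the source may have more. Where it says the series, first, only, none or still open, it means among the compounds named here.

Compound 1, `CN1CC(=O)N(C)c2cnc(Nc3ccc(S(N)(=O)=O)cc3)nc21`, in an assay on Sf9 cells for inhibition of serine/threonine-protein kinase 4 (Homo sapiens), read by luminescence and ADP-Glo, with a stated time of 1 h, in the presence of a further agent that is not named here (a higher number here means a weaker inhibitor, a lower number a stronger inhibitor), gives 495 nM.
Compound 2, `CN1C(=O)C(c2cccc(Cl)c2)N(C)c2nc(Nc3ccc(S(N)(=O)=O)cc3)ncc21`, gives 989 nM in this assay.
Compound 3, `COc1cccc(C2C(=O)N(C)c3cnc(Nc4ccc(S(N)(=O)=O)cc4)nc3N2C)c1`, gives 954 nM in this assay.

Compound 3 holds the second highest of the three numbers, but the steps separating it from its neighbours are small: a 1.0-fold lower number from compound 2 to compound 3 (0.02 log units; within the scatter), and a 1.9-fold higher number from compound 1 to compound 3 (0.28 log units; within the scatter). None of the three compounds can therefore be ranked against the others in this assay.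

Compound 4, `CN1C(=O)C(c2ccccc2C(F)(F)F)N(C)c2nc(Nc3ccc(S(N)(=O)=O)cc3)ncc21`, has not yet been measured. It differs from compound 3 in one place: 2-(trifluoromethyl)phenyl in place of 3-methoxyphenyl on a saturated ring carbon. Among the measured compounds shown here, two measured steps bear on this change. Adding an aryl group to that saturated ring carbon gave a 2.0-fold higher number from compound 1 to compound 2 (0.30 log units; within the scatter) and a 1.9-fold higher number from compound 1 to compound 3 (0.28 log units; within the scatter), and exchanging the substituent on that aryl gave a 1.0-fold lower number from compound 2 to compound 3 (0.02 log units; within the scatter). All three are within the scatter. For the measured compounds named here, no measured pair, however, introduces a trifluoromethyl group or moves the substituent to another position of the aryl ring, so the data give no direct precedent for compound 4.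

On this basis compound 4 is expected to sit near compound 3, with a step of a 1.0-fold higher number from compound 3 to compound 4 (0.02 log units; within the scatter), not beyond the scatter. The estimate for compound 4 in this assay is 1000 nM, with a range from 400 nM to 2500 nM.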

Compound 4, half-maximal inhibitory concentration: 56 nM
Estimate against measurement, compound 4: 18-fold (1.25 log units) above; measured number below the stated range.
By their numbers in this assay, from the lowest: compound 4; then compounds 1, 3 and 2 (each within the scatter of the next).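

In this assay, the aryl group on this saturated ring carbon proved able to shift the number well beyond the scatter: 2-(trifluoromethyl)phenyl gave large steps against both earlier aryl compounds (a 17-fold lower number from compound 3 to compound 4 (1.23 log units; beyond the scatter); an 18-fold lower number from compound 2 to compound 4 (1.25 log units; beyond the scatter)), whereas exchanging chloro for methoxy on the aryl ring had produced no readable change (a 1.0-fold lower number from compound 2 to compound 3 (0.02 log units; within the scatter)). The comparison with hydrogen on that carbon also changed: 3-chlorophenyl and 3-methoxyphenyl had stayed within the scatter of compound 1, but 2-(trifluoromethyl)phenyl gave a modest step beyond it (an 8.8-fold lower number from compound 1 to compound 4 (0.95 log units; beyond the scatter)), so an aryl group at this place is not simply neutral in this series. Nothing in the material available accounts for this difference between the aryl groups.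

Compound 4 differs from compounds 2 and 3 in both the substituent and its place on the aryl ring, so the compounds shown leave open whether the lower number belongs to the trifluoromethyl group, to its position, or to the two together. Plain phenyl, 2-chlorophenyl and 3-(trifluoromethyl)phenyl on that saturated ring carbon would bear on this question, and how an amine or a carboxylic acid on the aryl ring would read in this assay also remains open.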